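A Methyl Added to a Chain Under Plasma Test

This account rests on a few compounds, and the source may have more. Where it says the series, first, only, none or still open, it means among the compounds named here.

Of the compounds shown here, three sharing one core have been measured in an ADME assay on a cell-free system (plasma, Homo sapiens) for metabolic stability, read by LC-MS, with a stated time of 2 h, tested at 1 ug/mL; a higher number here means that more of the compound is left, a lower number that less of the compound is left. Compound 1 `CC(C)OC(=O)c1ccc(N)cc1O` gives 93%. Compound 2 `CC(C)OC(=O)OCOC(=O)c1ccc(N)cc1O`, which carries a longer chain on the same core, gives 0%. Compound 3 `CC(C)(C)C(=O)OCOC(=O)c1ccc(N)cc1O`, also with a longer chain, gives 15%. That places it second of the three, a little higher than compound 2 and far lower than compound 1.

The next compound, compound 4 `CC(OC(=O)c1ccc(N)cc1O)OC(=O)C(C)(C)C`, differs from compound 3 in one small way: methyl in place of hydrogen on a saturated chain carbon bound to two oxygens next to a carbonyl group. This is methyl in place of hydrogen on a saturated chain carbon bound to two oxygens next to a carbonyl group.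

Going by the values given here, only one measured step alters this chain, and it does so at a different place: a number 15 percentage points higher from compound 2 to compound 3 (beyond the scatter). Among the compounds with values here, that step was modest, and no measured compound carries the new methyl, so the guidance is weak and the range must stay wide. A change of similar size and direction seems the most reasonable expectation, and the estimated step is a number 15 percentage points higher from compound 3 to compound 4 (beyond the scatter). For compound 4, the estimated value in this assay is 30%, with an expected range from 10% to 60%.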

Compound 4, percent of the compound remaining: 0%
For compound 4 the middle estimate is 30 percentage points above the measured one; measured number below the stated range.
By their numbers in this assay, from the lowest: compounds 2 and 4 (each within the scatter of the next); then compound 3; then compound 1.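

This position is not a silent one: adding a single methyl to the saturated chain carbon bound to two oxygens next to a carbonyl group moves the result in this assay, with a number 15 percentage points lower from compound 3 to compound 4 (beyond the scatter). Going by these compounds alone, the only earlier step on this chain, made at a different place, went the other way, with a number 15 percentage points higher from compound 2 to compound 3 (beyond the scatter), so the two places on the chain do not move the number in the same direction. Compound 4 gives 0%, and since a percentage remaining can fall no further, the printed step may show only part of what this methyl does. Nothing available here explains why the number moves this way.

From the compounds shown here alone, whether size matters at this carbon stays open, since an ethyl group or a cyclopropyl ring there could give a different number from methyl. Going by these compounds, it is also open whether the same methyl would change anything on the isopropoxy carbonyl chain of compound 2, whose own value of 0% leaves no room for a further fall.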